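The compounds below may be only part of what the source reports. "The series", "measured", "known", "first", "only" and "open" are said of these compounds alone.

Compound 1, `COc1cc(/C=C/C(=O)c2cccc(-n3cc(-c4ccc(Cl)cc4)[nH]c3=O)c2)cc(OC)c1OC` — 31400 nM
Compound 2, `COc1cc(/C=C/C(=O)c2cccc(-n3cc(-c4ccccc4)[nH]c3=O)c2)ccc1O` — 3760 nM

Of the compounds shown here, two have been measured in a functional assay on SK-OV-3 cells (Homo sapiens) for inhibition; a lower number here means a stronger inhibitor of growth, a higher number a weaker inhibitor of growth. Compound 1 gives 31400 nM, the higher of the two numbers, so it is the weaker growth inhibitor of the pair; compound 2 gives 3760 nM, and the gap between the two lies beyond the usual scatter of this assay. The two compounds differ in more than one place, so no single structural change can be tied to that gap.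

Compound 3, `COc1cc(/C=C/C(=O)c2cccc(-n3cc(-c4cc(OC)c(OC)c(OC)c4)[nH]c3=O)c2)cc(OC)c1OC`, has not yet been measured. It differs from compound 1 in one place: 3,4,5-trimethoxyphenyl in place of 4-chlorophenyl on an aromatic carbon. The shared core, with its chalcone-type linker and the five-membered ring bearing two nitrogens, is unchanged.

Among the measured compounds shown here, because compound 1 sits at 31400 nM and no measured pair isolates this change, the expectation rests on the weak starting point alone. The writer expects a modest step toward stronger inhibition, a 2.1-fold lower number from compound 1 to compound 3 (0.32 log units; beyond the scatter), with wide uncertainty. Compound 3 is estimated at 15000 nM, within a range from 4000 nM to 50000 nM.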

Compound 3, concentration for 50% growth inhibition: 5120 nM
Estimate against measurement, compound 3: 2.9-fold (0.47 log units) above, and the stated range covers the measured number.
By their numbers in this assay, from the lowest: compounds 2 and 3 (each within the scatter of the next); then compound 1.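

In this assay, among the compounds shown here, 3,4,5-trimethoxyphenyl in place of 4-chlorophenyl gives a 6.1-fold lower number from compound 1 to compound 3 (0.79 log units; beyond the scatter), the first measured step that isolates a single change, and it shows that the group on this aromatic carbon of the five-membered ring bears on growth inhibition. The position accepts the larger group, with 12 heavy atoms against 7 and 3 hydrogen-bond acceptors against 0, and the number moves toward stronger inhibition rather than weaker. Nothing available explains why this exchange has that effect, and this single step cannot separate the loss of the chlorine from the gain of the methoxy groups, or from the larger size of the entering group.

From the compounds shown here alone, it remains open whether one methoxy group on this phenyl ring would give a step of similar size, and how a hydroxyl group, an amine or a carboxylic acid on the same ring would compare. Going by these compounds, it is also open whether the step would hold with a different substitution pattern elsewhere on the shared core.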